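Working notes on a small antiproliferative series

The source may report more compounds than this note shows. Statements on the series, on what has been measured and on what is new or still open speak of the compounds shown alone.

Measured so far:
compound 1 `CC1CCN(c2nc(Cl)nc3c2ncn3Cc2ccc(/C=C/C(=O)Nc3ccccc3N)cc2)CC1`, 26.9%
compound 2 `CCCCn1cnc2c(NCc3ccc(C(=O)Nc4ccccc4N)cc3)nc(Cl)nc21`, 40.9%

In a functional assay on HCT-116 cells (Homo sapiens) for antiproliferative activity, read by CCK-8 assay, with a stated time of 72 h, tested at 8 uM (a lower number here means a weaker effect, a higher number a stronger effect of the compound at the concentration tested), compound 1 stands lowest of the two numbers; its gap to compound 2 lies beyond the scatter. Compound 3 `Nc1ccccc1NC(=O)/C=C/c1ccc(Cn2cnc3c(Nc4cccc(OC(F)(F)F)c4)nc(Cl)nc32)cc1` differs from compound 1 in one place: (3-(trifluoromethoxy)phenyl)amino in place of 4-methylpiperidin-1-yl on an aromatic carbon. Within the data shown here, no step between measured compounds matches this change, so nothing measured fixes its direction or size. On the change alone a moderate rise is expected, a number 13.1 percentage points higher from compound 1 to compound 3 (beyond the scatter), probably beyond the scatter. Compound 3 is therefore expected at 40% in this assay, with a range from 22% to 60%.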

Compound 3, a percentage reported as inhibition, at one concentration (the size of the read-out at that concentration, not a potency): 5.23%
Beside the measured number, compound 3's estimate is 34.8 percentage points above it, outside the stated range (below it).
By their numbers in this assay, from the lowest: compound 3; then compound 1; then compound 2.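

At this position, on an aromatic carbon next to the ring nitrogen, the first readable step gives the change a direction: in this assay, (3-(trifluoromethoxy)phenyl)amino in place of 4-methylpiperidin-1-yl gives a number 21.7 percentage points lower from compound 1 to compound 3 (beyond the scatter). Nothing at hand accounts for this drop.

Open, as far as these compounds go, is whether the drop follows the aromatic ring or its trifluoromethoxy group, and how a plain phenylamino or a morpholine would read at this carbon. One step also does not show whether the change would read the same on the core of compound 2.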